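Chloro in place of fluoro: compound 1 to compound 4

This account rests on a few compounds, and the source may have more. Where it says the series, first, only, none or still open, it means among the compounds named here.

Measured so far in a functional assay on ECa-109 cells for inhibition, with ECa-109 cell line (Homo sapiens) as the target, read by sulforhodamine B assay; on this read-out lower numbers stand for stronger inhibition and higher numbers for weaker inhibition:
compound 1 `O=C1C=C(Nc2cccc(F)c2)C(=O)c2c1nc1n2[C@H]2OC[C@@H](O)[C@H]2OC1` gives 7030 nM.
compound 2 `O=C1C(Nc2ccc(C(F)(F)F)cc2)=CC(=O)c2c1nc1n2[C@H]2OC[C@@H](O)[C@H]2OC1` gives 2250 nM.
compound 3 `CCOc1ccc(NC2=CC(=O)c3c(nc4n3[C@H]3OC[C@@H](O)[C@H]3OC4)C2=O)cc1` gives > 4000 nM, which is a limit of the assay and not a number.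

Compound 1 stands at the highest of the two numbers in this assay; the nearest, compound 2, lies lower by a gap beyond the scatter, and compound 3 adds only a limit (the limit of > 4000 nM in this assay, at which 1 of the 3 values shown sits).

Compound 4 `O=C1C=C(Nc2cccc(Cl)c2)C(=O)c2c1nc1n2[C@H]2OC[C@@H](O)[C@H]2OC1` differs from compound 1 by chloro in place of fluoro on an aromatic carbon.

Going by the values given here, only one measured step is at hand, an at least 1.7-fold higher number from compound 2 to compound 3 (0.24 log units; that floor lies within the scatter), and it concerns other groups at another place, so it bears on the present change only loosely; its floor lies within the scatter. Among the compounds with values here, no measured step exchanges one halogen for another. The expectation for this assay is therefore a step near the scatter, if anything toward a slightly lower number.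

For compound 4 the expected value is 5000 nM, within 2000 nM to 12000 nM. The step expected is a 1.4-fold lower number from compound 1 to compound 4 (0.15 log units; within the scatter).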

Compound 4, half-maximal inhibitory concentration: 4690 nM
Compound 4: middle estimate off by 1.1-fold (0.03 log units), on the high side; the range from low to high includes it.
By their numbers in this assay, from the lowest: compound 2; then compounds 4 and 1 (each within the scatter of the next).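

In this assay, going by these compounds alone, this is the first halogen-for-halogen exchange, and the step, a 1.5-fold lower number from compound 1 to compound 4 (0.18 log units; within the scatter), gives no separation between (3-fluorophenyl)amino and (3-chlorophenyl)amino. At this aromatic carbon, then, the two halogens cannot be told apart on this read-out, although this rests on a single pair and supports no trend across halogens. Nothing in the data at hand accounts for the step.

Open, from the compounds shown here alone, is whether this aromatic carbon responds to anything other than a halogen, as a bromo, a methoxy, an amine or a carboxylic acid in the same place would show. Also open, going by these compounds, is whether the same exchange gives a similar step on other members, such as on the aromatic ring of compound 2.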